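A few compounds are considered here, and "the series" means these few. Any claim that something is new, unique, unknown or untested is made for them only; others in the source may bear on it.

Measured so far:
compound 1, `COc1ccc(CN(C(C)=O)c2cc(OC)c(OC)c(OC)c2)cc1O`: 160 nM
compound 2, `COc1ccc(CN(C(=O)C=C(C)C)c2cc(OC)c(OC)c(OC)c2)cc1O`: 280 nM
compound 3, `CCC/C=C/C(=O)N(Cc1ccc(OC)c(O)c1)c1cc(OC)c(OC)c(OC)c1`: 57 nM

The three share one core and differ only in the group on the carbonyl carbon. In a functional assay on KYSE-450 cells (Homo sapiens) for inhibition, read by MTT assay, with a stated time of 48 h (a lower number here means a stronger inhibitor, a higher number a weaker inhibitor), compound 3 gives the lowest of the three numbers; the nearest is compound 1, a 2.8-fold lower number from compound 1 to compound 3 (0.45 log units; beyond the scatter), and the furthest is compound 2, a 4.9-fold lower number from compound 2 to compound 3 (0.69 log units; beyond the scatter). Between the other two the difference is a 1.8-fold higher number from compound 1 to compound 2 (0.24 log units; within the scatter).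

Compound 4, `COc1ccc(CN(C(=O)C(C)C)c2cc(OC)c(OC)c(OC)c2)cc1O`, is not yet measured. Against compound 3 the change is isopropyl in place of pent-1-en-1-yl on a carbonyl carbon; unlike the leaving pent-1-en-1-yl, the entering isopropyl has no double bond outside aromatic rings. Within the data shown here, the steps that bear on this are the two into compound 3, a 2.8-fold lower number from compound 1 to compound 3 (0.45 log units; beyond the scatter) and a 4.9-fold lower number from compound 2 to compound 3 (0.69 log units; beyond the scatter), both a lower number on arriving at pent-1-en-1-yl from a shorter group. Going the other way, the number is expected to rise again, roughly back to where compound 1 stands. For compound 4 a step of a 3.2-fold higher number from compound 3 to compound 4 (0.50 log units; beyond the scatter) is expected. The estimate for compound 4 is 180 nM, with a range from 80 nM to 400 nM.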

Compound 4, half-maximal inhibitory concentration: 390 nM
For compound 4 the middle estimate is 2.2-fold (0.34 log units) below the measured one, and the stated range covers the measured number.
By their numbers in this assay, from the lowest: compound 3; then compounds 1, 2 and 4 (each within the scatter of the next, the first and the last beyond it).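

In this assay, among these compounds, exchanging the unbranched pent-1-en-1-yl for the saturated, branched isopropyl gives the largest step so far (a 6.8-fold higher number from compound 3 to compound 4 (0.84 log units; beyond the scatter)). The two branched groups cannot be told apart (a 1.4-fold higher number from compound 2 to compound 4 (0.14 log units; within the scatter), within the scatter), so in this branched pair the double bond outside aromatic rings makes no readable difference. Isopropyl also separates from methyl (a 2.4-fold higher number from compound 1 to compound 4 (0.39 log units; beyond the scatter)), so the number does not simply follow the size of the group on the carbonyl carbon: compound 3, with the largest group, goes against any such trend.

A saturated pentyl chain would show whether the low number of compound 3 goes with the double bond or with the unbranched chain. From the compounds shown here alone, the response to a longer chain, or to a cyclopropyl or phenyl group, also remains open. No measured evidence on the cause of these differences is available here.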